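A few compounds are considered here, and "the series" means these few. Any claim that something is new, unique, unknown or untested is made for them only; others in the source may bear on it.

The series shares one core, carried by compound 1 `CC(C(=O)N1C[C@H]2CCC[C@H]2C1)N1CCN(S(=O)(=O)c2ccc(C(C)(C)C)cc2)CC1`, compound 2 `C[C@@H](C(=O)N1CCCCC1)N1CCN(S(=O)(=O)c2ccc(C(C)(C)C)cc2)CC1` and compound 3 `CC(C(=O)N1CCCCCC1)N1CCN(S(=O)(=O)c2ccc(C(C)(C)C)cc2)CC1`, and the three differ only in the ring that sits on the carbonyl carbon. In an ADME assay on HepG2 cells (Homo sapiens) for inhibition, with a stated time of 48 h (a higher number here means that more compound is needed for the effect, a lower number that less compound is needed), compound 1 gives > 40000 nM, which is a limit of the assay rather than a number. In this assay compound 2 gives > 40000 nM, again a limit. In this assay compound 3 gives > 40000 nM, also a limit, so compound 3 stands where every other measured compound of the set stands. Within the data shown here, the only step between measured compounds that differ in one place is a step that the two limits leave unreadable from compound 1 to compound 3. Compound 4 `CC(C(=O)N1CCC(C)(C)CC1)N1CCN(S(=O)(=O)c2ccc(C(C)(C)C)cc2)CC1` is not yet measured; it differs from compound 3 by 4,4-dimethylpiperidin-1-yl in place of azepan-1-yl on a carbonyl carbon. No measured step can be read for this kind of change, because of the limit of > 40000 nM in this assay, at which 3 of the 3 values shown sit. The step from compound 3 to compound 4 can therefore be bounded only from one side, and it is expected to be no larger than the scatter, a step that the limit leaves unreadable from compound 3 to compound 4. Compound 4 is expected to give 50000 nM in this assay, within an estimated range from 20000 nM to 200000 nM, and most likely again reported only as a limit.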

Compound 4, half-maximal effective concentration: > 40000 nM
Compound 4 was reported as a limit; the forecaster's own chance of this, stated with the estimate: 85%; the middle value lies beyond the limit too.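

In this assay compound 4 gives > 40000 nM, a limit of the assay. No new step can be read, as the steps from compound 3 and from compound 1 to compound 4 each join two limits: the limit of > 40000 nM in this assay, at which 4 of the 4 values shown sit. The compounds shown leave open whether any ring on the carbonyl carbon alters the half-maximal effective concentration.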